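This account rests on a few compounds, and the source may have more. Where it says the series, first, only, none or still open, it means among the compounds named here.

Of the compounds shown here, three of one series have been tested in a functional assay on A-375 cells (Homo sapiens) for cytotoxicity, read by MTT assay, with a stated time of 72 h, tested at 3 uM; on this read-out higher numbers stand for more inhibition of growth at the one concentration tested and lower numbers for less inhibition of growth. Compound 1 `N/C(=N\NC(=S)N1CCOCC1)c1ccccn1` gives 19.3%. Compound 2 `Cc1cccc(/C(N)=N/NC(=S)N2CCSCC2)n1` gives 60.1%. Compound 3 `N/C(=N\NC(=S)N1CCSCC1)c1ccccn1` gives 80%. On these numbers compound 2 stands second of the three: compound 3 lies above it by a number 19.9 percentage points higher from compound 2 to compound 3 (beyond the scatter), while compound 1 lies well below it.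

The next compound, compound 4 `Cc1cccc(/C(N)=N/NC(=S)N2CCOCC2)n1`, is compound 2 with one change: morpholin-4-yl in place of thiomorpholin-4-yl on a thiocarbonyl carbon. Among the compounds with values here, this is the reverse of the only step that touches the same place, where a thiomorpholin-4-yl took the place of a morpholin-4-yl on the thiocarbonyl carbon and brought a number 60.7 percentage points higher from compound 1 to compound 3 (beyond the scatter). The other known step, a hydrogen in place of a methyl on an aromatic carbon, gave a number 19.9 percentage points higher from compound 2 to compound 3 (beyond the scatter) and bears on the change only in showing that the methyl-bearing core of compound 2 behaves much like that of compound 3.

Turning the thiomorpholin-4-yl back into a morpholin-4-yl is therefore expected to cost a large part of the growth inhibition of compound 2, a step estimated at a number 48.1 percentage points lower from compound 2 to compound 4 (beyond the scatter) in this assay. Compound 4 is accordingly expected to give about 12%, with a likely range from 0% to 35%.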

Compound 4, percent growth inhibition at one concentration: 34.7%
The estimate for compound 4 lay 22.7 percentage points below the measured number, and the stated range covers the measured number.
By their numbers in this assay, from the lowest: compound 1; then compound 4; then compound 2; then compound 3.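

Compound 4 shows that morpholin-4-yl on the thiocarbonyl carbon also gives less growth inhibition than thiomorpholin-4-yl when the aromatic methyl is present, with a number 25.4 percentage points lower from compound 2 to compound 4 (beyond the scatter) in this assay. The direction of the change thus holds on both cores, but its size does not: the same change on two cores in this assay, a number 60.7 percentage points higher (beyond the scatter) from compound 1 to compound 3 and a number 25.4 percentage points higher (beyond the scatter) from compound 4 to compound 2, 35.3 percentage points apart, beyond the scatter of two such steps. The methyl on the aromatic carbon also behaves differently from one core to the other, since it goes with a lower number among the thiomorpholin-4-yl compounds yet brings a number 15.4 percentage points higher from compound 1 to compound 4 (beyond the scatter) among the morpholin-4-yl compounds, so the sign of this step reverses: the same change on two cores in this assay, a number 19.9 percentage points higher (beyond the scatter) from compound 2 to compound 3 and a number 15.4 percentage points lower (beyond the scatter) from compound 4 to compound 1, 35.3 percentage points apart, beyond the scatter of two such steps.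

The compounds shown leave open whether another group on the thiocarbonyl carbon, such as piperidin-1-yl or dimethylamino, would track thiomorpholin-4-yl or morpholin-4-yl, and whether an ethyl or a chlorine in place of the methyl on the aromatic carbon would also depend on the group at the thiocarbonyl carbon. From the compounds shown here alone, each number also comes from one concentration, so it remains open whether the order of the four compounds would hold across a range of concentrations.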